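Notes on a halogen swap from compound 2

A few compounds are considered here, and "the series" means these few. Any claim that something is new, unique, unknown or untested is made for them only; others in the source may bear on it.

In an ADME assay on the whole organism for pharmacokinetics, with Rattus norvegicus as the target (a higher number here means that a larger share of the oral dose reaches the circulation, a lower number that a smaller share of the oral dose reaches the circulation), compound 1 (`O=S(=O)(c1ccc(F)cc1)c1cc(Cl)c(O)c2ncccc12`) gives 23% and compound 2 (`O=S(=O)(c1cc(F)c(O)c2ncccc12)N1CCCC1`) gives 73% as the highest of the two numbers, a gap beyond the scatter. Compound 3 (`O=S(=O)(c1cc(Cl)c(O)c2ncccc12)N1CCCC1`) carries chloro in place of fluoro on an aromatic carbon, ortho to a hydroxy group. Among the compounds with values here, no measured step isolates this change. Compound 1 also carries chloro but differs from compound 3 elsewhere, so it gives only weak guidance. A moderate fall in this assay is expected, with an estimated a number 18 percentage points lower from compound 2 to compound 3 (beyond the scatter) as its size. Compound 3 is expected at 55% within a range from 32% to 78% as estimated here.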

Compound 3, oral bioavailability: 33%
Estimate against measurement, compound 3: 22 percentage points above; measured number inside the range.
By their numbers in this assay, from the lowest: compounds 1 and 3 (each within the scatter of the next); then compound 2.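

In this assay, chloro in place of fluoro on an aromatic carbon, ortho to a hydroxy group, gives a large step, a number 40 percentage points lower from compound 2 to compound 3 (beyond the scatter), so this position does not tolerate the swap without loss. With chloro held constant, pyrrolidin-1-yl in place of 4-fluorophenyl on a sulfonyl sulfur gives a number 10 percentage points higher from compound 1 to compound 3 (within the scatter), which does not separate the two groups. Nothing at hand bears on the reason for the fall.

Open, as far as these compounds go, is how a methoxy group or a nitrile on this aromatic carbon would read in this assay. Also open, from the compounds shown here alone, is whether the halogen step carries over to a sulfonyl sulfur bearing 4-fluorophenyl.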